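From Nitrophenyl to Pyrrolyl on the Carbonyl Carbon

The compounds below may be only part of what the source reports. "The series", "measured", "known", "first", "only" and "open" are said of these compounds alone.

Measured compounds:
compound 1 `COc1ccc(-c2cc3ccccc3nc2/C=C/C(=O)c2c(OC)cccc2OC)cc1`: 7410 nM
compound 2 `COc1ccc(-c2cc3ccccc3nc2/C=C/C(=O)c2ccc([N+](=O)[O-])cc2)cc1`: 6310 nM

In a functional assay on A549 cells (Homo sapiens) for antiproliferative activity, read by XTT assay, with a stated time of 72 h (a lower number here means a stronger inhibitor, a higher number a weaker inhibitor), compound 1 gives 7410 nM and compound 2 gives 6310 nM. Compound 2 holds the lowest number of the two, yet the step of a 1.2-fold lower number from compound 1 to compound 2 (0.07 log units; within the scatter) lies within the scatter, so the two cannot be ranked. Compound 3 `COc1ccc(-c2cc3ccccc3nc2/C=C/C(=O)c2ccc[nH]2)cc1` carries the change (1H-pyrrol-2-yl in place of 4-nitrophenyl on a carbonyl carbon). Among the compounds with values here, the single measured step also exchanged the group on the carbonyl carbon and moved nothing beyond the scatter, so for compound 3 no step beyond the scatter in this assay is expected. Compound 3 is estimated at 7000 nM (range 2500 nM to 20000 nM), an expected step of a 1.1-fold higher number from compound 2 to compound 3 (0.05 log units; within the scatter).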

Compound 3, half-maximal inhibitory concentration: > 10000 nM
Compound 3 ended at the assay's limit; the forecaster's own chance of this, stated with the estimate: 10%; middle value at least 1.4-fold (0.15 log units) away from the limit.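

Compound 3 gives > 10000 nM in this assay, which is a limit of the assay and not a number: the limit of > 10000 nM in this assay, at which 1 of the 3 values shown sits. Placing 1H-pyrrol-2-yl on the carbonyl carbon in place of 4-nitrophenyl gives an at least 1.5-fold higher number from compound 2 to compound 3 (0.19 log units; that floor lies within the scatter), and placing it there in place of 2,6-dimethoxyphenyl gives an at least 1.3-fold higher number from compound 1 to compound 3 (0.13 log units; that floor lies within the scatter). So this five-membered ring, the first group here with a hydrogen-bond donor, brings no gain, though these floors do not establish a real loss.

From the compounds shown here alone, how far compound 3 lies past the limit stays open. So does whether an aminophenyl group on this carbonyl carbon would give a lower number.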